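A few compounds are considered here, and "the series" means these few. Any claim that something is new, unique, unknown or untested is made for them only; others in the source may bear on it.

Measured in a functional assay on CWR22R cells (Homo sapiens) for antiproliferative activity, read by luminescence, with a stated time of 96 h; on this read-out higher numbers stand for weaker inhibition and lower numbers for stronger inhibition:
- compound 1 `CC1(C)Oc2cc(NS(=O)(=O)C3CCCCC3)ccc2NC1=O`: 8020 nM
- compound 2 `CC1(C)Oc2cc(NS(=O)(=O)c3ccccc3)ccc2NC1=O`: 13100 nM
- compound 3 `COc1cc2c(cc1NS(=O)(=O)c1cc(Br)ccc1OC)OC(C)(C)C(=O)N2`: 3380 nM

Compound 3 stands lowest of the three, with both other values beyond the scatter from it. The change to compound 4 `COc1ccc(Br)cc1S(=O)(=O)Nc1cc2c(cc1O)NC(=O)C(C)(C)O2` is hydrogen in place of methyl on an oxygen on an aromatic ring, methoxy to hydroxy. Among the measured compounds shown here, the only measured step, a 1.6-fold higher number from compound 1 to compound 2 (0.21 log units; within the scatter), is phenyl in place of cyclohexyl on a sulfonyl sulfur. For the measured compounds named here, it lies elsewhere on the structure, so no measured step covers this change. No shift beyond the scatter is therefore expected in this assay, and the small lean to a higher number is a guess. The expected step is a 1.5-fold higher number from compound 3 to compound 4 (0.17 log units; within the scatter). The estimate for compound 4 is 5000 nM, with a range of 1800 nM to 14000 nM.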

Compound 4, half-maximal inhibitory concentration: 7590 nM
Compound 4: middle estimate off by 1.5-fold (0.18 log units), on the low side, within the range that was stated.
By their numbers in this assay, from the lowest: compound 3; then compounds 4, 1 and 2 (each within the scatter of the next).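

Replacing methyl with hydrogen on an oxygen on an aromatic ring, methoxy to hydroxy, gives in this assay a step of a 2.2-fold higher number from compound 3 to compound 4 (0.35 log units; beyond the scatter). Among the compounds shown here, this is the only measured change at this position, and it shows that the methoxy to hydroxy change moves the number modestly but beyond the scatter, whereas the one earlier step, a 1.6-fold higher number from compound 1 to compound 2 (0.21 log units; within the scatter), on a sulfonyl sulfur, stayed within it. Nothing at hand accounts for the size or direction of this step.

Still open, from the compounds shown here alone, is how a longer chain on this oxygen, such as ethoxy, would compare with methoxy and hydroxy. Going by these compounds, an amine in place of the hydroxy is equally open.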